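The source may report more compounds than this note shows. Statements on the series, on what has been measured and on what is new or still open speak of the compounds shown alone.

Compound 1 `O=C1CCC(N2C(=O)c3cccc(Nc4ccccc4)c3C2=O)C(=O)N1` stands lowest of the two numbers seen so far in an assay on FRT-Jurkat cells for inhibition of nuclear factor NF-kappa-B complex (Homo sapiens), read by flow cytometry, with a stated time of 24 h, tested at 10 uM (on this read-out higher numbers stand for more inhibition at the one concentration tested (going by the name of the read-out) and lower numbers for less inhibition), where compound 1 gives 4%. Among the compounds with values here, the only other measured compound, compound 2 `CCCc1ccc(Nc2ccc3c(c2)C(=O)N(C2CCC(=O)NC2=O)C3=O)cc1`, is not a single-point neighbour of compound 1; in this assay compound 2 gives 10%, and the two values lie within the scatter of each other, so nothing separates them. Compound 3 `CCc1ccc(Nc2cccc3c2C(=O)N(C2CCC(=O)NC2=O)C3=O)cc1` differs from compound 1 in one place: ethyl in place of hydrogen on an aromatic carbon, on an aromatic carbon of a six-membered aromatic ring of carbon only. Within the data shown here, no step between measured compounds bears on this change, and the only comparison available, compound 2 with 10% against compound 1 with 4%, shows no difference beyond the scatter. The step from compound 1 to compound 3 is therefore expected to be a number 4 percentage points higher from compound 1 to compound 3 (within the scatter), nothing beyond the scatter in either direction. Compound 3 is estimated at 8% in this assay, within a range of 0% to 22%.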

Compound 3, a percentage reported as inhibition, at one concentration (the size of the read-out at that concentration, not a potency): 17%
The estimate for compound 3 lay 9 percentage points below the measured number; the range from low to high includes it.
By their numbers in this assay, from the lowest: compounds 1, 2 and 3 (each within the scatter of the next, the first and the last beyond it).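

In this assay, within the data shown here, the change from phenyl to 4-ethylphenyl gives the first step that clears the scatter: a number 13 percentage points higher from compound 1 to compound 3 (beyond the scatter). This shows that the read-out can respond to a substituent at this place on the ring, para to a large group, and that ethyl there does not abolish inhibition, although the step is modest. Nothing at hand accounts for the step.

As far as these compounds go, it remains open whether a butyl chain or a methyl group at the same place would give a larger or smaller step, and whether an amine or a carboxylic acid there would move the number the other way. Compound 2 differs from compound 3 in more than one place, so it does not settle the question of chain length.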